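Shifting the hydroxyl on the ester ring of compound 3

The compounds below may be only part of what the source reports. "The series", "measured", "known", "first", "only" and "open" are said of these compounds alone.

In an ADME assay on a cell-free system (plasma, Homo sapiens) for metabolic stability, with Plasma (Rattus norvegicus) as the target, read by HPLC, at pH 7.4 (a lower number here means that the compound disappears faster, a higher number that the compound lasts longer), compound 1 `CC(=O)Oc1ccccc1C(=O)O[C@H]1CO[C@H]2[C@@H]1OC[C@H]2OC(=O)c1snnc1C` gives 0.0065 h.
In this assay compound 2 `CC(=O)Oc1ccccc1C(=O)O[C@H]1CO[C@H]2[C@@H]1OC[C@H]2O` gives 0.0183 h.
In this assay compound 3 `CC(=O)Oc1ccccc1C(=O)O[C@H]1CO[C@H]2[C@@H]1OC[C@H]2OC(=O)c1cccc(O)c1` gives 0.015 h.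

Compound 3 stands second highest of the three numbers: against compound 2 the step of a 1.2-fold lower number from compound 2 to compound 3 (0.09 log units; within the scatter) lies within the scatter, while against compound 1 the step of a 2.3-fold higher number from compound 1 to compound 3 (0.36 log units; beyond the scatter) lies beyond it. Compound 4 `CC(=O)Oc1ccccc1C(=O)O[C@H]1CO[C@H]2[C@@H]1OC[C@H]2OC(=O)c1ccc(O)cc1` differs from compound 3 in one place: 4-hydroxyphenyl in place of 3-hydroxyphenyl on a carbonyl carbon. Among the measured compounds shown here, no measured step shifts a hydroxyl on this ring. The nearest comparison is the step of a 1.2-fold lower number from compound 2 to compound 3 (0.09 log units; within the scatter), where adding the entire (3-hydroxyphenyl)carbonyl group changed nothing beyond the scatter, so rearranging the hydroxyl within that group is expected to matter little. The expected step is no change at the digits printed from compound 3 to compound 4 (within the scatter), none beyond the scatter. For compound 4 the estimate is 0.015 h, between 0.007 h and 0.032 h.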

Compound 4, half-life: 0.0198 h
Estimate against measurement, compound 4: 1.3-fold (0.12 log units) below; the measured number falls inside the stated range.
By their numbers in this assay, from the lowest: compound 1; then compounds 3, 2 and 4 (each within the scatter of the next).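

In this assay the shift to 4-hydroxyphenyl gives a 1.3-fold higher number from compound 3 to compound 4 (0.12 log units; within the scatter) and so shows that, on this carbonyl carbon, where the hydroxyl sits on the ring makes no readable difference. The (4-hydroxyphenyl)carbonyl group also reads level with plain hydrogen on that oxygen, with a 1.1-fold higher number from compound 2 to compound 4 (0.03 log units; within the scatter) as the step. Compound 1 alone stands apart, with a 3.0-fold higher number from compound 1 to compound 4 (0.48 log units; beyond the scatter) as the step for 4-hydroxyphenyl in place of 4-methyl-1,2,3-thiadiazol-5-yl on the carbonyl carbon.

Nothing available gives a reason for these numbers. From the compounds shown here alone, whether an amine or a carboxylic acid on this ring would move the half-life beyond the scatter remains open.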